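A bromo added to compound 1

A few compounds are considered here, and "the series" means these few. Any claim that something is new, unique, unknown or untested is made for them only; others in the source may bear on it.

Measured in a functional assay on MIA PaCa-2 cells (Homo sapiens) for antiproliferative activity, read by sulforhodamine B assay, with a stated time of 48 h; a lower number here means a stronger inhibitor, a higher number a weaker inhibitor:
compound 1 `COc1ccc2nc(-c3ccc(N/C=C\C(=O)c4cc(OC)c(OC)c(OC)c4)c(C)c3)sc2c1` gives 10000 nM
compound 2 `COc1ccc2nc(-c3ccc(N/C=C\C(=O)c4ccc(OC)c(O)c4)cc3)sc2c1` gives 21900 nM
compound 3 `COc1ccc2nc(-c3ccc(N/C=C\C(=O)c4cc(OC)c(OC)c(OC)c4)cc3)sc2c1` gives 31100 nM

Compound 1 has the lowest number of these three, which makes it the strongest inhibitor among them. Compound 4 `COc1ccc2nc(-c3ccc(N/C=C\C(=O)c4cc(OC)c(OC)c(OC)c4Br)c(C)c3)sc2c1` is compound 1 with a single change, bromo in place of hydrogen on an aromatic carbon on the ring that carries the methoxy groups.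

Among the compounds with values here, the only measured comparison with a single change is a 3.1-fold higher number from compound 1 to compound 3 (0.49 log units; beyond the scatter) when a methyl on an aromatic carbon gives way to hydrogen. Within the data shown here, this modest step involves a methyl on a different ring, so it shows only that one small change can move the number. Among the measured compounds shown here, it gives no direction for a bromo, and no measured compound carries one. For the measured compounds named here, no step clearly beyond the scatter is therefore expected in this assay, and either direction remains possible. The estimate is a 1.1-fold lower number from compound 1 to compound 4 (0.05 log units; within the scatter) as a central guess. For compound 4 the expected value is 9000 nM with an estimated range from 2500 nM to 32000 nM across repeated measurements.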

Compound 4, half-maximal inhibitory concentration: 23400 nM
Beside the measured number, compound 4's estimate is 2.6-fold (0.41 log units) below it; low and high end bracket the measured number.
By their numbers in this assay, from the lowest: compound 1; then compounds 2, 4 and 3 (each within the scatter of the next).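

In this assay, a bromo on the ring that carries the methoxy groups gives a 2.3-fold higher number from compound 1 to compound 4 (0.37 log units; beyond the scatter) and so makes compound 4 a weaker inhibitor than compound 1. The earlier single-change step concerned a methyl on a different ring, whereas this one shows that the number also responds to a change on the methoxy-bearing ring, at the carbon ortho to a methoxy group. No measurement shown here accounts for this loss of activity.

On these data alone, whether a fluoro or an amine on that same carbon would also raise the number remains open, since one group cannot show how this position responds to substituents in general. Also open, as far as these compounds go, is whether the bromo would cause a similar step in compound 3, which lacks the methyl present in compound 1.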